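This account rests on a few compounds, and the source may have more. Where it says the series, first, only, none or still open, it means among the compounds named here.

Working notes on the series. Compound 1 `Cc1ccnc(NC(c2ccc([N+](=O)[O-])cc2)c2ccc3cccnc3c2O)c1` and compound 2 `COc1ccc(C(Nc2ccccn2)c2ccc3cccnc3c2O)cc1` share a core and have both been run in an ADME assay on a cell-free system (plasma, Homo sapiens) for metabolic stability, read by LC-MS, with a stated time of 3 h, tested at 1 uM; a lower number here means that less of the compound is left, a higher number that more of the compound is left. In this assay, for the measured compounds named here, compound 1 gives 90.9%, and in this assay compound 2 gives 53.4%, the lowest of the two numbers so far; the gap between compound 2 and compound 1 lies beyond the scatter. Going by the values given here, no two measured compounds differ in one place only, so no single measured step is available. Compound 3 `Oc1c(CNc2ccccn2)ccc2cccnc12` is the next entry and has not yet been measured in this assay. Relative to compound 2 it carries hydrogen in place of 4-methoxyphenyl on a saturated chain carbon bound to an aromatic carbon and a nitrogen on an aromatic ring. A step of moderate size in the upward direction is expected, a number 11.6 percentage points higher from compound 2 to compound 3 (beyond the scatter), and it may still fall within the scatter. Compound 3 is estimated to give 65% in this assay, with a range from 40% to 88%.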

Compound 3, percent of the compound remaining in the plasma assay: 96.1%
For compound 3 the middle estimate is 31.1 percentage points below the measured one; measured number outside the range, above it.
By their numbers in the plasma assay, from the lowest: compound 2; then compounds 1 and 3 (each within the scatter of the next).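

For the compounds shown here, the change of 4-methoxyphenyl to hydrogen on the saturated chain carbon gives the first step that can be read at a single place: in the plasma assay there is a number 42.7 percentage points higher from compound 2 to compound 3 (beyond the scatter). In a physicochemical assay for solubility, using the shake flask method, with a stated time of 24 h, at pH 1 (on this read-out higher numbers stand for higher solubility and lower numbers for lower solubility), compound 2 gives 102000 nM and compound 3 gives 1140000 nM, so the compound with hydrogen at this position has the higher number on both read-outs. Nothing measured here gives a cause for the step in the plasma assay, and the solubility numbers do not supply one.

Compound 1 also carries an aromatic group on this carbon but differs from compound 2 and compound 3 in more than one place, so it cannot show whether any such group lowers the number. As far as these compounds go, whether a methyl, an unsubstituted phenyl or a carboxylic acid on this carbon would sit nearer compound 2 or compound 3 remains open.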